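Adding a Phenyl Branch to an Alpha-1 Binder

This account rests on a few compounds, and the source may have more. Where it says the series, first, only, none or still open, it means among the compounds named here.

Of the compounds shown here, two share a common core and have been measured in an assay on Prostate gland (Oryctolagus cuniculus) for inhibition of Adrenergic receptor alpha-1 (Homo sapiens); on this read-out higher numbers stand for weaker binding and lower numbers for tighter binding. Compound 1 `COc1ccccc1NC(=O)c1ccc(OCCCN2CCN(c3ccccc3OC)CC2)cc1` gives 79.4 nM in this assay. Compound 2 `COc1ccccc1N1CCN(CCCOc2ccc(C(=O)Nc3ccccc3OCCCC(=O)O)cc2)CC1` gives 100 nM. Among the compounds with values here, the only measured step, a 1.3-fold higher number from compound 1 to compound 2 (0.10 log units; within the scatter), changes nothing beyond the scatter, and compound 2 has the highest of the two numbers, with compound 1 nearest to it and within the scatter.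

Compound 3 `COc1ccccc1N1CCN(CCC(Oc2ccc(C(=O)Nc3ccccc3OCCCC(=O)O)cc2)c2ccccc2)CC1` has not yet been measured in this assay. Its difference from compound 2 is phenyl in place of hydrogen on a saturated chain carbon bound to an oxygen on an aromatic ring and a saturated chain carbon. Within the data shown here, no measured step touches this kind of change: the one step on record, from compound 1 to compound 2, adds a 2-carboxyethyl on another chain and left the number within the scatter, so it says nothing about a phenyl entering here.

With no direct guidance, the expectation for compound 3 is a modest shift, estimated as a 1.6-fold higher number from compound 2 to compound 3 (0.20 log units; within the scatter), with the direction uncertain. Compound 3 is therefore expected to give about 160 nM in this assay, with a range from 30 nM to 800 nM.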

Compound 3, dissociation constant: 25.1 nM
Estimate against measurement, compound 3: 6.4-fold (0.80 log units) above, outside the stated range (below it).
By their numbers in this assay, from the lowest: compound 3; then compounds 1 and 2 (each within the scatter of the next).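

In this assay, phenyl in place of hydrogen on a saturated chain carbon bound to an oxygen on an aromatic ring and a saturated chain carbon gives a 4.0-fold lower number from compound 2 to compound 3 (0.60 log units; beyond the scatter) and so moves binding beyond the scatter, toward tighter binding. Within the data shown here, the earlier step, a 1.3-fold higher number from compound 1 to compound 2 (0.10 log units; within the scatter) for a 2-carboxyethyl on another chain, left the number within the scatter, so this is the first change on record that shifts the read-out, and it shows that this chain carbon is a place where a substituent can matter. No measurement here bears on what lies behind the gain from the added ring.

The compounds shown cover only phenyl at this carbon, so it remains open whether a small group such as methyl, or another ring such as cyclohexyl, would give a step of similar size, or whether any gain needs an aromatic ring at all. Going by these compounds, it also remains open whether phenyl at this carbon would give a similar step on the core of compound 1, which lacks the 2-carboxyethyl.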